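Replacing a benzyl ether with a 4-cyanophenyl ether

The compounds below may be only part of what the source reports. "The series", "measured", "known", "first", "only" and "open" are said of these compounds alone.

Of the compounds shown here, three sharing one core have been measured in an ADME assay on Vero cells (Chlorocebus sabaeus) for cytotoxicity, read by luminescence, with a stated time of 2 days; on this read-out higher numbers stand for lower toxicity in this test and lower numbers for higher toxicity in this test. Compound 1 `CCc1nc2ccccc2n1CCCCOc1cccc(C)c1` gives 19 uM, compound 2 `CCc1nc2ccccc2n1CCCCOCc1ccccc1` gives 32 uM, and compound 3 `CCc1nc2ccccc2n1CCCCOc1ccccc1Cl` gives 16 uM. Compound 2 carries the largest of the three numbers, but neither gap reaches beyond the scatter: the step of a 1.7-fold higher number from compound 1 to compound 2 (0.23 log units; within the scatter) and the step of a 2.0-fold lower number from compound 2 to compound 3 (0.30 log units; within the scatter) are both small, as is a 1.2-fold lower number from compound 1 to compound 3 (0.07 log units; within the scatter).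

Compound 4 `CCc1nc2ccccc2n1CCCCOc1ccc(C#N)cc1` has not yet been measured in this assay. It differs from compound 2 by 4-cyanophenyl in place of benzyl on an oxygen on a saturated carbon. Among the compounds with values here, the steps that bear on this change are the two that swap a benzyl for an aromatic ring bound directly to the oxygen, a 1.7-fold higher number from compound 1 to compound 2 (0.23 log units; within the scatter) read in reverse and a 2.0-fold lower number from compound 2 to compound 3 (0.30 log units; within the scatter); both were within the scatter. Within the data shown here, the 4-cyanophenyl group brings one hydrogen-bond acceptor that neither compound 1 nor compound 3 has, and no measured step tells what that does here.

Compound 4 is therefore expected to land close to compound 2, with at most a modest downward step of a 1.6-fold lower number from compound 2 to compound 4 (0.20 log units; within the scatter) in this assay. The estimate for compound 4 is 20 uM, with a range from 8 uM to 50 uM.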

Compound 4, half-maximal toxic concentration: 27 uM
Beside the measured number, compound 4's estimate is 1.4-fold (0.13 log units) below it, and the stated range covers the measured number.
By their numbers in this assay, from the lowest: compounds 3, 1, 4 and 2 (each within the scatter of the next).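

In this assay the hydrogen-bond acceptor that enters with the 4-cyanophenyl group does not separate compound 4 from the benzyl ether (the step reads a 1.2-fold lower number from compound 2 to compound 4 (0.07 log units; within the scatter)), and the same holds against the two other ethers with a ring bound directly to the oxygen (a 1.7-fold higher number from compound 3 to compound 4 (0.23 log units; within the scatter); a 1.4-fold higher number from compound 1 to compound 4 (0.15 log units; within the scatter)). The earlier compounds had shown this only for groups without a nitrile, so this place on the oxygen has now taken four different groups, including one with a triple bond and an acceptor, with no step beyond the scatter among those listed. No measurement shown here accounts for this result or says what the nitrile itself contributes.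

Since all four compounds lie within the scatter of their neighbours, the compounds shown do not reveal which kind of group on this oxygen, if any, would change the number in this assay beyond the scatter. An amine or a carboxylic acid on the ring, or a longer chain between the oxygen and the shared core, remains an open test of how far this tolerance extends.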